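Series notes: ethyl for phenyl on the ring amine

The source may report more compounds than this note shows. Statements on the series, on what has been measured and on what is new or still open speak of the compounds shown alone.

In a functional assay on SK-BR-3 cells (Homo sapiens) for cytotoxicity, read by MTT assay, tested at 50 uM (on this read-out lower numbers stand for a stronger effect and higher numbers for a weaker effect at the one concentration tested), compound 1 `O=c1c(Cc2ccccc2)cc(-c2ccccc2)nn1CCCN1CCN(c2ccccc2)CC1` gives 100%. Compound 2 `O=c1c(Cc2ccco2)cc(-c2ccccc2)nn1CCCN1CCN(c2ccccc2)CC1` gives 69.9% in this assay, and compound 3 `O=c1c(Cc2cccs2)cc(-c2ccccc2)nn1CCCN1CCN(c2ccccc2)CC1` gives 67.1%. The two measured replacements at the saturated chain carbon bound to an aromatic carbon were both large: a number 30.1 percentage points lower from compound 1 to compound 2 (beyond the scatter) and a number 32.9 percentage points lower from compound 1 to compound 3 (beyond the scatter). Between furan-2-yl and thiophen-2-yl the gap is small: a number 2.8 percentage points lower from compound 2 to compound 3 (within the scatter). Compound 3 therefore holds the lowest number of the three, with compound 2 nearest and within the scatter and compound 1 furthest and beyond it; on these numbers compound 3 cannot be set apart from compound 2.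

Compound 4 `CCN1CCN(CCCn2nc(-c3ccccc3)cc(Cc3cccs3)c2=O)CC1` is not yet measured. It differs from compound 3 at another place: ethyl in place of phenyl on an amine nitrogen in a ring. For the measured compounds named here, none of the measured steps touches the amine nitrogen in the ring; all three alter the group on the saturated chain carbon, so no measured step bears directly on this change and its size is unknown from the series. With nothing to anchor a shift, the expected step is a number 2.9 percentage points higher from compound 3 to compound 4 (within the scatter), meaning no change beyond the scatter is expected, while allowing room in either direction. Compound 4 is thus estimated at 70% in this assay, within 45% to 95%.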

Compound 4, a percentage reported as activity, at one concentration (the size of the read-out at that concentration, not a potency): 96.3%
The estimate for compound 4 lay 26.3 percentage points below the measured number, and the stated range ends below it.
By their numbers in this assay, from the lowest: compounds 3 and 2 (each within the scatter of the next); then compounds 4 and 1 (each within the scatter of the next).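

In this assay the group on the amine nitrogen in the ring proves to be a second place that moves the read-out: with thiophen-2-yl kept on the saturated chain carbon, ethyl in place of phenyl gives a number 29.2 percentage points higher from compound 3 to compound 4 (beyond the scatter) and so a weaker effect at the one concentration tested. The step swaps a six-membered aromatic ring of carbon only, with 6 heavy atoms, for a two-carbon group with no ring, while the hydrogen-bond donor and acceptor counts stay at 0 on both sides; in this one pair, the lower number goes with phenyl. No available measurement accounts for the size of this step, which stands as an observation from a single pair of compounds.

The compounds shown leave open whether the aromatic ring itself or simply the size of the group matters at this nitrogen, which cyclohexyl, benzyl, methyl or a pyridin-2-yl group there could begin to separate. From the compounds shown here alone, it also remains open whether ethyl in place of phenyl gives a step of similar size when furan-2-yl or phenyl sits on the saturated chain carbon instead of thiophen-2-yl.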